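This account rests on a few compounds, and the source may have more. Where it says the series, first, only, none or still open, it means among the compounds named here.

Compound 1 `Nc1ccc(-c2cc(=O)c3c(N)c(F)c(O)c(F)c3o2)cc1F`: in a functional assay on MCF7 cells (Homo sapiens) for cytotoxicity, read by neutral red uptake, with a stated time of 3 days (on this read-out higher numbers stand for weaker inhibition and lower numbers for stronger inhibition), compound 1 gives > 10000 nM, which is a limit of the assay and not a number.
Compound 2 `Nc1ccc(-c2cc(=O)c3c(N)c(F)c(Cl)c(F)c3o2)cc1F`: in this assay compound 2 gives 210 nM.

For the measured compounds named here, compound 2 thus stands as the only number in the set; the other value is a limit. One step is measured between the two, an at least 47-fold lower number from compound 1 to compound 2 (1.67 log units; beyond the scatter), chloro in place of hydroxy on an aromatic carbon, and its size rests on (the limit of > 10000 nM in this assay, at which 1 of the 2 values shown sits).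

Compound 3 `[N-]=[N+]=Nc1c(F)c(N)c2c(=O)cc(-c3ccc(N)c(F)c3)oc2c1F` differs from compound 2 by azido in place of chloro on an aromatic carbon. Going by the values given here, no measured step exchanges chloro for azido. Among the compounds with values here, the one measured step at this carbon was large, but it exchanged a different pair of groups, so it fixes neither the size nor the direction of the present change. The expectation for compound 3 is therefore a step not far beyond the scatter, leaning toward a somewhat higher number, a 2.1-fold higher number from compound 2 to compound 3 (0.33 log units; beyond the scatter). Compound 3 is estimated at 450 nM in this assay, with a range from 120 nM to 2500 nM.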

Compound 3, half-maximal inhibitory concentration: 460 nM
Beside the measured number, compound 3's estimate is 1.0-fold (0.01 log units) below it; the range from low to high includes it.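

The exchange of chloro for azido at this carbon can now be read directly in this assay, and it comes out as a 2.2-fold higher number from compound 2 to compound 3 (0.34 log units; beyond the scatter). Azido in place of hydroxy gives an at least 21-fold lower number from compound 1 to compound 3 (1.33 log units; beyond the scatter), so the large step seen with chloro is not unique to chloro: both groups that replace hydroxy here give a large step, and the step between the two of them is only modest. From the compounds shown here alone, the size of both steps from hydroxy remains open-ended, as compound 1 has only a limit of the assay: the limit of > 10000 nM in this assay, at which 1 of the 3 values shown sits.

Only hydroxy, chloro and azido are shown at this carbon, so how a bromo, a methoxy or a nitrile group would read there remains open, as does where the hydroxy effect begins to appear among such groups. Also open, going by these compounds, is whether the modest step between chloro and azido would hold with the two fluoro groups replaced by hydrogen, or on a core with a different group in place of the amino group.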